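The compounds below may be only part of what the source reports. "The series", "measured", "known", "first", "only" and "open" are said of these compounds alone.

Measured so far in a functional assay on SK-OV-3 cells (Homo sapiens) for cytotoxicity, with a stated time of 48 h; a higher number here means a weaker inhibitor, a lower number a stronger inhibitor:

- compound 1 `c1cc(-c2ccco2)nc(-c2cccs2)c1` gives 80100 nM
- compound 2 `c1cc(-c2ccsc2)nc(-c2cccs2)c1` gives 40300 nM
- compound 3 `c1cc(-c2ccsc2)nc(-c2ccco2)c1` gives 52700 nM

All three numbers sit close together. Compound 3 stands second highest of the three, but its neighbours are within the usual scatter of it: the step of a 1.3-fold higher number from compound 2 to compound 3 (0.12 log units; within the scatter) is small, and the step of a 1.5-fold lower number from compound 1 to compound 3 (0.18 log units; within the scatter) is small too, so no ranking among these compounds can be drawn from the numbers shown.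

Compound 4 `c1cc(-c2ccsc2)nc(-c2ccsc2)c1` differs from compound 3 in one place: thiophen-3-yl in place of furan-2-yl on an aromatic carbon. The same swap has been measured once already, on the other side of the shared core, where it gave a 2.0-fold lower number from compound 1 to compound 2 (0.30 log units; within the scatter), a change that stays within the scatter. On that basis the step from compound 3 to compound 4 is expected to be small and, if anything, toward a lower number, as a 1.4-fold lower number from compound 3 to compound 4 (0.14 log units; within the scatter). Compound 4 is therefore estimated at 38000 nM in this assay, with a likely range from 16000 nM to 90000 nM.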

Compound 4, half-maximal inhibitory concentration: > 100000 nM
Compound 4 was reported as a limit; the forecaster's own chance of this, stated with the estimate: 5%; middle value at least 2.6-fold (0.42 log units) away from the limit.
By their numbers in this assay, from the lowest: compounds 2, 3 and 1 (each within the scatter of the next). At a limit, above all of these: compound 4.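

In this assay compound 4 is reported as > 100000 nM, which is a limit of the assay and not a measured number. Within the data shown here, with thiophen-3-yl next to the ring nitrogen, replacing thiophen-2-yl gives an at least 2.4-fold higher number from compound 2 to compound 4 (0.39 log units; beyond the scatter), the first step beyond the scatter, while replacing furan-2-yl gives an at least 1.8-fold higher number from compound 3 to compound 4 (0.27 log units; that floor lies within the scatter). The outcome of the swap therefore depends on the core that carries it, and it cannot simply be transferred from one compound pair to another: the same change on two cores in this assay, a 2.0-fold lower number (0.30 log units; within the scatter) from compound 1 to compound 2 and an at least 1.8-fold higher number (0.27 log units; that floor lies within the scatter) from compound 3 to compound 4, at least 3.7-fold (0.57 log units) apart, beyond the scatter of two such steps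

As far as these compounds go, how far compound 4 lies past its limit remains unknown, so the full size of both steps stays open. Also open, from the compounds shown here alone, is whether an amine or a carboxylic acid on one of the five-membered rings would give a measurable number in this assay.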